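The source may hold more compounds than are shown below. What is called first, only, known or untested is meant among the compounds shown, and "the series" means these compounds.

Compound 1 `COc1cc(/C=C2\CN(C)C/C(=C\c3ccc(Cl)cc3)C2=O)cc(OC)c1OC` and compound 2 `COc1cc(/C=C2\CN(C)C/C(=C\c3ccc(Br)cc3)C2=O)cc(OC)c1OC` share one core, while compound 3 `CN1C/C(=C\c2ccc(Cl)cc2)C(=O)/C(=C/c2ccc(C#N)cc2)C1` and compound 4 `CN1C/C(=C\c2ccc(Br)cc2)C(=O)/C(=C/c2ccc(C#N)cc2)C1` share another; the difference between the two cores is not broken down here. In a functional assay on HeLa cells (Homo sapiens) for cytotoxicity, read by MTT assay, with a stated time of 24 h (a lower number here means a stronger inhibitor, a higher number a weaker inhibitor), compound 1 reaches only a limit of the assay, > 20000 nM. Compound 2 gives 11900 nM in this assay. Compound 3 gives 11200 nM in this assay, a number within the scatter of that of compound 2.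

Among the compounds with values here, the single measured step, an at least 1.6-fold lower number from compound 1 to compound 2 (0.22 log units; that floor lies within the scatter), is the change (bromo in place of chloro on an aromatic carbon). Its size can only be given as a floor because of the limit of > 20000 nM in this assay, at which 1 of the 3 values shown sits, so the true step may be larger than the floor shows.

The same change is now made on the other core: compound 4 differs from compound 3 by bromo in place of chloro on an aromatic carbon. The place of the change reads the same in both pairs, so it is the same change, only on a different core. A step of about the size of the floor seen from compound 1 to compound 2, an at least 1.6-fold lower number from compound 1 to compound 2 (0.22 log units; that floor lies within the scatter), is therefore expected from compound 3 to compound 4, namely a 1.4-fold lower number from compound 3 to compound 4 (0.15 log units; within the scatter), though with wide room on either side, since that floor itself lies within the scatter. Compound 4 is thus estimated at 8000 nM in this assay, expected to fall between 3500 nM and 18000 nM.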

Compound 4, half-maximal inhibitory concentration: 5900 nM
For compound 4 the middle estimate is 1.4-fold (0.13 log units) above the measured one; low and high end bracket the measured number.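

Replacing 4-chlorophenyl with 4-bromophenyl on the second core gives a 1.9-fold lower number from compound 3 to compound 4 (0.28 log units; within the scatter), a step that lies within the usual scatter of repeated measurements. Set beside the earlier step, it points the same way, which fits the change carrying over from one core to the other, but the size of the two steps cannot be compared exactly: the same change on two cores in this assay, an at least 1.6-fold lower number (0.22 log units; that floor lies within the scatter) from compound 1 to compound 2 and a 1.9-fold lower number (0.28 log units; within the scatter) from compound 3 to compound 4; the limit leaves it open whether they differ. This does not show that bromo truly gives a lower number than chloro in this assay, since neither step stands clear of the scatter, and the first step cannot be pinned down because one of its two ends is not a true number: the limit of > 20000 nM in this assay, at which 1 of the 4 values shown sits.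

The compounds shown carry only chloro or bromo in this place, so it remains open how fluoro, iodo or an amine on the same aromatic carbon would read in this assay. Within the data shown here, with only two cores in view, it also remains open whether the same change would follow this direction on a third core, or whether a clearer step would appear on a core whose starting value is not a limit.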